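This account rests on a few compounds, and the source may have more. Where it says the series, first, only, none or still open, it means among the compounds named here.

Compound 1 `Cc1c(CCCC(=O)O)c2cccc(/C=C/c3ccc(OCCCCc4c(F)c(F)cc(F)c4F)cc3)c2n1CC(=O)O` was examined in a physicochemical assay for permeability, using PAMPA, with a stated time of 4 h, at pH 6.2, tested at 50 uM (on this read-out lower numbers stand for lower permeability and higher numbers for higher permeability), where compound 1 gives 9.4 10^-6 cm/s. Two other compounds sharing the core were also measured. Compound 2 `O=C(O)CCCn1cc(CC(=O)O)c2c(/C=C/c3ccc(OCCCCOc4ccccc4)cc3)cccc21` gives 6.9 10^-6 cm/s in this assay, and compound 3 `O=C(O)CCCc1cn(CC(=O)O)c2c(/C=C/c3ccc(OCCCCOc4ccccc4)cc3)cccc12` gives 1.6 10^-6 cm/s. On the numbers shown, compound 1 has the highest figure of the three, but the figure of compound 2 lies within the usual scatter of it, so the two cannot be told apart; only compound 3 falls clearly beyond the scatter, with a markedly lower number.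

The step from compound 1 to compound 4 `Cc1c(CCCC(=O)O)c2cccc(/C=C/c3ccc(OCCCCc4c(F)ccc(F)c4F)cc3)c2n1CC(=O)O` is a single change: hydrogen in place of fluoro on an aromatic carbon. Within the data shown here, no pair of measured compounds differs by exactly this change, so there is no measured step to lean on. The loss of one fluorine from the 2,3,5,6-tetrafluorobenzyl group is a small change in the counted atoms, and the expectation is that compound 4 will give a number close to that of compound 1, with any shift, if it appears, leaning slightly downward but remaining within the scatter. The step is estimated to be a 1.2-fold lower number from compound 1 to compound 4 (0.07 log units; within the scatter), an expected shift that would stay within the scatter. Compound 4 is therefore estimated to give 8 10^-6 cm/s in this assay, with a range from 4.5 10^-6 cm/s to 14 10^-6 cm/s.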

Compound 4, apparent permeability: 4.4 10^-6 cm/s
For compound 4 the middle estimate is 1.8-fold (0.26 log units) above the measured one, outside the stated range (below it).
By their numbers in this assay, from the lowest: compound 3; then compounds 4, 2 and 1 (each within the scatter of the next, the first and the last beyond it).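

Taking one fluoro off the ring, so that the 2,3,5,6-tetrafluorobenzyl group becomes the 2,3,6-trifluorobenzyl group, gives a 2.1-fold lower number from compound 1 to compound 4 (0.33 log units; beyond the scatter) in this assay, and this is the first step in the series that can be read at a single place. It shows that the read-out responds to the exchange of just one heavy atom on this aromatic carbon, which stands ortho to a fluoro group, para to another and meta to a large group, while the rest of compound 1 stays the same. The compounds shown offer no measurement that accounts for this step.

As far as these compounds go, it remains open whether the step belongs to this particular ring carbon or would recur on removal of another fluoro group from the same ring, and whether it would hold on a different ring or chain within the shared core. From the compounds shown here alone, it is equally open where a chlorine atom, a methyl group or a methoxy group on this carbon would fall relative to the fluoro and hydrogen of compound 1 and compound 4.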